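Replacing the (pyridin-4-yl)sulfanyl group with bromo

This account rests on a few compounds, and the source may have more. Where it says the series, first, only, none or still open, it means among the compounds named here.

Of the compounds shown here, three sharing one core have been measured in a functional assay (microsomes, liver) with Rattus norvegicus as the target; on this read-out higher numbers stand for weaker inhibition and lower numbers for stronger inhibition. Compound 1 (`Cc1c(C)c2c(c(C)c1N)CC(C)(CSc1ccncc1)O2`) gives 630 nM, the highest number of the three. Compound 2 (`Cc1c(C)c2c(c(C)c1N)CC(C)(CSCc1ccccc1)O2`) gives 260 nM, and compound 3 (`Cc1c(C)c2c(c(C)c1N)CC(C)(COCc1ccccc1)O2`) gives 280 nM. These last two values lie within the scatter of each other, and both sit below that of compound 1.

Compound 4 (`Cc1c(C)c2c(c(C)c1N)CC(C)(CBr)O2`) has not yet been measured. It differs from compound 1 by a single change, bromo in place of (pyridin-4-yl)sulfanyl on a saturated chain carbon bound to a saturated ring carbon.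

Among the compounds with values here, only one measured step bears on this change: a 2.4-fold lower number from compound 1 to compound 2 (0.38 log units; beyond the scatter), with benzyl in place of pyridin-4-yl on a sulfur. That step is modest, and it keeps the sulfur, which compound 4 loses, so it is only a loose guide. Within the data shown here, no bromo compound has been measured for comparison. In this assay, a step no larger than that modest one is therefore expected, tilted toward a lower number and probably not beyond the scatter. The estimated step is a 1.4-fold lower number from compound 1 to compound 4 (0.15 log units; within the scatter). For compound 4, the estimated value is 450 nM, with an expected range from 180 nM to 1100 nM.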

Compound 4, half-maximal inhibitory concentration: 300 nM
The estimate for compound 4 lay 1.5-fold (0.18 log units) above the measured number; low and high end bracket the measured number.
By their numbers in this assay, from the lowest: compounds 2, 3 and 4 (each within the scatter of the next); then compound 1.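

In this assay the exchange of (pyridin-4-yl)sulfanyl for bromo on a saturated chain carbon bound to a saturated ring carbon gives a 2.1-fold lower number from compound 1 to compound 4 (0.32 log units; beyond the scatter) and so goes the same way as the benzyl step on the sulfur. The earlier compounds shown here all carried a six-membered aromatic ring in this group, whereas compound 4 shows that neither that ring nor the sulfur is needed here for a number at this level. Compound 4, with a single bromine atom, gives 300 nM and compound 2, with its much larger benzylsulfanyl group, gives 260 nM, two values within the scatter of each other; no measurement available here explains why the number falls with this change.

The compounds shown leave open whether bromine itself matters at this place or whether the number would hold with chloro, a hydroxyl or a primary amine on the same chain carbon. They also leave open how a plain methyl group, carrying no added atom at this place, would compare with compound 4 on this read-out.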